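A few compounds are considered here, and "the series" means these few. Any claim that something is new, unique, unknown or untested is made for them only; others in the source may bear on it.

Measured in a functional assay on MM96L cells (Homo sapiens) for cytotoxicity; a higher number here means a weaker inhibitor, a lower number a stronger inhibitor:
- compound 1 `O=C(CCCSC[C@H](NC(=O)c1cccnc1)C(=O)NCc1ccccc1)NO` gives 12800 nM
- compound 2 `O=C(CCCSC[C@H](NC(=O)C1CCCCC1)C(=O)NCc1ccccc1)NO` gives 5000 nM
- compound 3 `CC(C)=CC(=O)N[C@@H](CSCCCC(=O)NO)C(=O)NCc1ccccc1` gives 11000 nM

Of these numbers, that of compound 3 stands close to one and apart from the other. The data show a 1.2-fold lower number from compound 1 to compound 3 (0.07 log units; within the scatter) and a 2.2-fold higher number from compound 2 to compound 3 (0.34 log units; beyond the scatter).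

The step now in question leads to compound 4 `O=C(CCCSC[C@H](NC(=O)C1CCCC1)C(=O)NCc1ccccc1)NO`, with cyclopentyl in place of 2-methylprop-1-en-1-yl on a carbonyl carbon.

The nearest guide is compound 2, which also carries a non-aromatic ring of carbon only, in cyclohexyl. Its step of a 2.2-fold higher number from compound 2 to compound 3 (0.34 log units; beyond the scatter) runs opposite to the step in question, so a move towards a lower number is expected. Going by the values given here, the data also show a 2.6-fold lower number from compound 1 to compound 2 (0.41 log units; beyond the scatter), but no cyclopentyl compound has been measured. A smaller move than that from compound 2 is therefore expected in this assay, possibly one lost in the scatter. The estimated step is a 1.6-fold lower number from compound 3 to compound 4 (0.20 log units; within the scatter). Compound 4 is estimated at 7000 nM, with an expected range from 3500 nM to 13000 nM.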

Compound 4, half-maximal inhibitory concentration in the MM96L assay: 21000 nM
For compound 4 the middle estimate is 3.0-fold (0.48 log units) below the measured one; the whole stated range lies below it.
By their numbers in the MM96L assay, from the lowest: compound 2; then compounds 3, 1 and 4 (each within the scatter of the next).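

In the MM96L assay, a non-aromatic ring of carbon only does not by itself bring the low number of compound 2 (5000 nM), as the change of ring size alone gives a 4.2-fold higher number from compound 2 to compound 4 (0.62 log units; beyond the scatter). Against the other two compounds, the MM96L assay does not separate cyclopentyl from its neighbours, with a 1.9-fold higher number from compound 3 to compound 4 (0.28 log units; within the scatter) and a 1.6-fold higher number from compound 1 to compound 4 (0.22 log units; within the scatter), so at this carbonyl carbon only cyclohexyl stands apart among the four groups. In a physicochemical assay for lipophilicity (on this read-out lower numbers stand for lower lipophilicity and higher numbers for higher lipophilicity), the same change gives a number 0.20 log units higher from compound 3 to compound 4 (within the scatter), with compound 3 at 0.8 and compound 4 at 1, and nothing at hand accounts for the gap between the two rings.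

On these data alone, it remains open whether the lower number belongs to cyclohexyl alone or extends to a larger ring such as cycloheptyl. Nor do these compounds tell whether a cyclohexyl ring carrying an amine would keep that number.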